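This account rests on a few compounds, and the source may have more. Where it says the series, first, only, none or still open, it means among the compounds named here.

Compound 3 `CC(C)(O)c1cncc(-n2ncc3ccc(F)cc32)c1` belongs to a small set of compounds built on a shared core. In an ADME assay on cells for inhibition of cytochrome P450 11B1, mitochondrial (Homo sapiens), read by HTRF, with stated times of 1 h and 3 h (on this read-out higher numbers stand for weaker inhibition and lower numbers for stronger inhibition), compound 3 gives 1990 nM, the highest of the two numbers shown; the nearest is compound 1 `CC(C)(O)c1cncc(-n2ncc3ccccc32)c1` with 535 nM. Compound 2 `CC(C)(O)c1cncc(-n2nc(C3CC3)c3ccccc32)c1` gives > 8300 nM in this assay, which is a limit of the assay and not a number. The step from compound 1 to compound 3 was a 3.7-fold higher number from compound 1 to compound 3 (0.57 log units; beyond the scatter), with fluoro in place of hydrogen on an aromatic carbon. The step from compound 1 to compound 2 was an at least 15-fold higher number from compound 1 to compound 2 (1.19 log units; beyond the scatter), with cyclopropyl in place of hydrogen on an aromatic carbon, its end resting at the limit of > 8300 nM in this assay, at which 1 of the 3 values shown sits.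

Compound 4 `CC(C)(O)c1cncc(-n2ncc3ccc(C(F)(F)F)cc32)c1` differs from compound 3 by trifluoromethyl in place of fluoro on an aromatic carbon. Both measured steps placed a group on an aromatic carbon of the core and raised the number, the modest step with fluoro and the large step with cyclopropyl. A further rise beyond the scatter is therefore expected in this assay, and the estimated step is a 3.0-fold higher number from compound 3 to compound 4 (0.48 log units; beyond the scatter). Compound 4 is expected to give about 6000 nM, with a range from 2000 nM to 15000 nM.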

Compound 4, half-maximal inhibitory concentration: > 8300 nM
Compound 4 gave a limit, no number (the forecaster's own chance of this, stated with the estimate: 30%); middle value at least 1.3-fold (0.14 log units) from the limit.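

In this assay, this aromatic carbon of the shared core proves sensitive to more than fluoro alone: putting trifluoromethyl in place of fluoro gives an at least 4.1-fold higher number from compound 3 to compound 4 (0.62 log units; beyond the scatter), and the same group in place of hydrogen gives an at least 15-fold higher number from compound 1 to compound 4 (1.19 log units; beyond the scatter). Among the compounds shown, both groups placed here raise the number, and trifluoromethyl raises it further than fluoro, so a second, different group now confirms the direction at this position. Compound 4 stands at a limit of the assay, not at a number: the limit of > 8300 nM in this assay, at which 2 of the 4 values shown sit.

On these data alone, how far the true value of compound 4 lies past that limit remains unknown. Also open, as far as these compounds go, is whether any group on this carbon, such as an amine or a methoxy group, would give a lower number than compound 1 at 535 nM.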